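The source may hold more compounds than are shown below. What is called first, only, known or untested is meant among the compounds shown, and "the series" means these compounds.

Measured so far in a functional assay on MCF7 cells (Homo sapiens) for inhibition, read by MTT assay, with a stated time of 48 h; on this read-out higher numbers stand for weaker inhibition and lower numbers for stronger inhibition:
- Compound 1 `CCOC(=O)C1=C(N/N=C(\c2ccc([N+](=O)[O-])cc2)N2CCN(c3ccc(F)cc3)CC2)Nc2[nH]nc(C)c2C1c1ccc(N(C)C)cc1`: > 100000 nM
- Compound 2 `CCOC(=O)C1=C(NN=C(C#N)C#N)Nc2[nH]nc(C)c2C1c1ccc(N(C)C)cc1`: 12100 nM

The entry for compound 1 is a limit of the assay and not a number: the limit of > 100000 nM in this assay, at which 1 of the 2 values shown sits. For the measured compounds named here, compound 2, at 12100 nM, therefore holds the only actual number so far, and it is the natural point of comparison for what follows.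

The next compound to be tested is compound 3 `CCOC(=O)C1=C(N/N=C(/Cl)C#N)Nc2[nH]nc(C)c2C1c1ccc(N(C)C)cc1`, which has not yet been measured. It keeps the shared core of compound 2 and differs from it in one group, on an amine nitrogen whose other neighbours are a double-bonded ring carbon: a group of 5 heavy atoms (2 carbon, 2 nitrogen, 1 chlorine; no ring) in place of a group of 6 heavy atoms (3 carbon, 3 nitrogen; no ring), on an amine nitrogen. A group of 5 heavy atoms thus takes the place of a group of 6 heavy atoms, and neither contains a ring.

Going by the values given here, no measured pair differing in one place is available to guide the size of this step in this assay. With so small a change from compound 2 at 12100 nM, no shift beyond the usual scatter is expected, and no firm direction can be given. The expected step is a 1.2-fold lower number from compound 2 to compound 3 (0.08 log units; within the scatter). For compound 3 the estimated value is 10000 nM, with an expected range of 3000 nM to 35000 nM.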

Compound 3, half-maximal inhibitory concentration: 23200 nM
Estimate against measurement, compound 3: 2.3-fold (0.37 log units) below, within the range that was stated.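

At the amine nitrogen whose other neighbours are a double-bonded ring carbon, this assay now gives a step that can be read as a number: a 1.9-fold higher number from compound 2 to compound 3 (0.28 log units; within the scatter). The exchange puts a group of 5 heavy atoms, with 1 chlorine, 1 triple bond and 2 hydrogen-bond acceptors, in place of a group of 6 heavy atoms with 2 triple bonds and 3 hydrogen-bond acceptors, and on this read-out compound 2 and compound 3 cannot be told apart, so this position tolerates this particular change without a shift beyond the usual scatter. Compound 1, which carries a different group at the same nitrogen, remains a limit of the assay and not a number, and no step to it can be read: the limit of > 100000 nM in this assay, at which 1 of the 3 values shown sits.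

The compounds shown leave open how this position responds to a group without a nitrile, such as an amide or a carboxylic acid, or to bromine in place of the chlorine. They also leave open the role of the rest of the shared core, which is the same in every compound shown.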